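The source may hold more compounds than are shown below. What is called first, only, known or untested is meant among the compounds shown, and "the series" means these compounds.

Measured compounds:
- compound 1 `COc1ccc(NC(=O)COC(=O)/C=C/c2cc(OC)c(OCc3ccc(Cl)c(Cl)c3)c(OC)c2)cc1`: > 200000 nM, a limit of the assay
- compound 2 `CCOc1ccc(COc2c(OC)cc(/C=C/C(=O)OCC(=O)Nc3ccccc3)cc2OC)cc1`: > 200000 nM, a limit of the assay
- compound 3 `COc1cc(/C=C/C(=O)OCC(=O)Nc2ccc(Cl)cc2)cc(OC)c1OCc1ccc(Cl)c(Cl)c1`: 72400 nM

Going by the values given here, in a functional assay on LS174T cells (Homo sapiens) for cytotoxicity, read by MTT assay, with a stated time of 72 h (on this read-out higher numbers stand for weaker inhibition and lower numbers for stronger inhibition), compound 3 holds the only number in the set; the other two results are limits. Among the compounds with values here, the one measured step, an at least 2.7-fold lower number from compound 1 to compound 3 (0.44 log units; beyond the scatter), is the only change so far that moved a value off (the limit of > 200000 nM in this assay, at which 2 of the 3 values shown sit).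

Compound 4 `CCOc1ccc(COc2c(OC)cc(/C=C/C(=O)OCC(=O)Nc3ccc(Cl)cc3)cc2OC)cc1` is not yet measured. Its difference from compound 3 is 4-ethoxyphenyl in place of 3,4-dichlorophenyl on a saturated chain carbon bound to an oxygen on an aromatic ring. Within the data shown here, no measured step covers this change. The closest information is compound 2, which carries the same 4-ethoxybenzyl group and the unsubstituted anilide; in this assay compound 2 gives > 200000 nM, which is a limit. Compound 1, carrying the 3,4-dichlorobenzyl group with the methoxy anilide, likewise gives > 200000 nM, a limit. These two limits cannot be ordered against each other, so the benzyl change itself has no measured size here.

Given that compound 3 stands close to the limit of > 200000 nM in this assay, at which 2 of the 3 values shown sit, already, the expectation for compound 4 is a weaker result, with a real chance that only a limit is returned. The step from compound 3 to compound 4 is expected to be a 2.1-fold higher number from compound 3 to compound 4 (0.32 log units; beyond the scatter). Compound 4 is estimated at 150000 nM, in the range 50000 nM to 400000 nM.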

Compound 4, half-maximal inhibitory concentration: > 200000 nM
Compound 4 was reported as a limit; the forecaster's own chance of this, stated with the estimate: 50%; middle value at least 1.3-fold (0.12 log units) away from the limit.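

In this assay, going by these compounds alone, the change from 3,4-dichlorobenzyl to 4-ethoxybenzyl now has a readable size for the first time, an at least 2.7-fold higher number from compound 3 to compound 4 (0.44 log units; beyond the scatter), with the rest of the molecule held constant. Compound 3 alone keeps a number, and each single change shown away from it, at the anilide in compound 1 or at the benzyl group in compound 4, ends at a limit: the limit of > 200000 nM in this assay, at which 3 of the 4 values shown sit.

The step between compound 2 and compound 4, chloro in place of hydrogen on an aromatic carbon, cannot be read, as both results are limits.

Open, from the compounds shown here alone, is whether the loss at the benzyl position tracks the departure of the two chlorines or the arrival of the ethoxy group, a question that a plain benzyl, a 4-chlorobenzyl or a 4-methoxybenzyl group could separate in this assay. Also open, going by these compounds, is whether a number can be kept or improved when the ester link of the shared core gives way to an amide, or when the anilide carries a bromo or a trifluoromethyl group in place of chloro.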